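Aryl group exchange at the saturated ring carbon

The compounds below may be only part of what the source reports. "The series", "measured", "known", "first", "only" and "open" are said of these compounds alone.

Among the compounds with values here, compound 2 `COC(=O)C1=C(C)N=C(C)/C(=C(\O)OC)C1c1ccc(Cl)cc1` gives 8130 nM in a functional assay (muscle tissue) with Cavia porcellus as the target (on this read-out higher numbers stand for an effect only at larger amounts of compound and lower numbers for an effect already at smaller amounts), the highest of the two numbers measured so far. Compound 1 `COC(=O)C1=C(C)N=C(C)/C(=C(\O)OC)C1c1cc([N+](=O)[O-])ccc1O` gives 100 nM in this assay, a gap beyond the scatter between two compounds that differ only in the aryl group on the saturated ring carbon. Compound 3 `COC(=O)C1=C(C)N=C(C)/C(=C(\O)OC)C1c1ccccc1I` carries 2-iodophenyl in place of 4-chlorophenyl on a saturated ring carbon. Within the data shown here, no measured step of this exact kind exists, so any expectation rests on that wide spread alone. For compound 3 a fall in the number is expected, of roughly a 20-fold lower number from compound 2 to compound 3 (1.31 log units; beyond the scatter). Compound 3 is estimated at 400 nM, within 60 nM to 3000 nM.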

Compound 3, half-maximal effective concentration: 46.8 nM
Estimate against measurement, compound 3: 8.5-fold (0.93 log units) above; the whole stated range lies above it.
By their numbers in this assay, from the lowest: compound 3; then compound 1; then compound 2.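

In this assay, 2-iodophenyl in place of 4-chlorophenyl gives a 170-fold lower number from compound 2 to compound 3 (2.24 log units; beyond the scatter), so this position responds strongly to a change that leaves the heavy-atom count of the group the same. The nitro and hydroxyl groups of compound 1 are not needed for a low number: compound 3 gives 46.8 nM, and compound 1 gives 100 nM. Nothing available accounts for the size of this step.

As far as these compounds go, the halogen and its place on the phenyl ring change together, so their shares in the step remain open. 2-Chlorophenyl or 4-iodophenyl would separate them, and 2-aminophenyl would test a non-halogen group.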